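A few compounds are considered here, and "the series" means these few. Any claim that something is new, unique, unknown or untested is made for them only; others in the source may bear on it.

Of the compounds shown here, three sharing one core have been tested in a functional assay on cells (T-cell, Mus musculus, strain BALB/c) for inhibition, read by MTT assay, with stated times of 24 h and 72 h; on this read-out higher numbers stand for weaker inhibition and lower numbers for stronger inhibition. Compound 1 `COc1cc(-c2nnc(SCc3cccc(Br)c3)o2)ccc1O` gives 48100 nM. Compound 2 `COc1cc(-c2nnc(SCc3ccc(C)cc3)o2)ccc1O` gives 6210 nM, and compound 3 `COc1cc(-c2nnc(SCc3ccccc3Cl)o2)ccc1O` gives 8430 nM. Two changes to the ring on the saturated chain carbon bound to a sulfur brought the number down: a 7.7-fold lower number from compound 1 to compound 2 (0.89 log units; beyond the scatter) and a 5.7-fold lower number from compound 1 to compound 3 (0.76 log units; beyond the scatter). The gap between the two lower compounds is small: a 1.4-fold higher number from compound 2 to compound 3 (0.13 log units; within the scatter). Compound 3 therefore stands second highest of the three, close to compound 2 and far from compound 1.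

Compound 4 `COc1cc(-c2nnc(SCc3ccccc3C)o2)ccc1O` differs from compound 3 in one place: methyl in place of chloro on an aromatic carbon. Going by the values given here, no measured pair swaps chloro for methyl on the same aromatic carbon; the nearest guide is compound 2 against compound 3, where the step of a 1.4-fold higher number from compound 2 to compound 3 (0.13 log units; within the scatter) stayed within the scatter even though both the group and its place changed. The step from compound 3 to compound 4 is therefore expected to be small, a 1.1-fold lower number from compound 3 to compound 4 (0.05 log units; within the scatter), with no clear direction. Compound 4 is expected to give about 7500 nM, within a range from 3000 nM to 19000 nM.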

Compound 4, half-maximal inhibitory concentration: 8420 nM
Compound 4: middle estimate off by 1.1-fold (0.05 log units), on the low side; low and high end bracket the measured number.
By their numbers in this assay, from the lowest: compounds 2, 4 and 3 (each within the scatter of the next); then compound 1.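

In this assay, methyl and chloro on this aromatic carbon, ortho to a large group, cannot be told apart: the result is a 1.0-fold lower number from compound 3 to compound 4 (0.00 log units; within the scatter). The 2-methylphenyl and 4-methylphenyl rings also fall within the scatter of each other, with a 1.4-fold higher number from compound 2 to compound 4 (0.13 log units; within the scatter), whereas the 3-bromophenyl ring remains the outlier, with a 5.7-fold lower number from compound 1 to compound 4 (0.76 log units; beyond the scatter). Nothing measured here explains why these rings compare as they do.

Going by these compounds, it remains open whether a quite different group on this aromatic carbon, such as an amine or a carboxylic acid, would stay level with chloro and methyl or give a clearly different number. It is also open whether the gap for compound 1 comes from the bromine itself or from where it sits, as the 3-bromophenyl ring is the only bromine-bearing ring among these compounds.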